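The compounds below may be only part of what the source reports. "The series", "measured", "known", "first", "only" and "open" are said of these compounds alone.

Working notes on the series in a functional assay on A549 cells (Homo sapiens) for cytotoxicity, read by MTT assay, with a stated time of 48 h; on this read-out lower numbers stand for stronger inhibition and higher numbers for weaker inhibition.

Three compounds share one core and differ only in the aryl group on a carbon with a double bond to nitrogen. Compound 1 `COc1ccc(OC)c(C2=NOC(COc3ccc(-c4nnnn4-c4cc(OC)c(OC)c(OC)c4)cc3N)C2)c1` gives 1930 nM. Compound 2 `COc1ccc(C2=NOC(COc3ccc(-c4nnnn4-c4cc(OC)c(OC)c(OC)c4)cc3N)C2)cc1OC` gives 2520 nM. Compound 3 `COc1ccc(C2=NOC(COc3ccc(-c4nnnn4-c4cc(OC)c(OC)c(OC)c4)cc3N)C2)cc1[N+](=O)[O-]` gives 2220 nM. Compound 2 has the highest of the three numbers, but its gaps to both neighbours are small: a 1.3-fold higher number from compound 1 to compound 2 (0.12 log units; within the scatter), and a 1.1-fold lower number from compound 2 to compound 3 (0.06 log units; within the scatter). The third pair is likewise flat, a 1.2-fold higher number from compound 1 to compound 3 (0.06 log units; within the scatter). None of the three aryl swaps seen so far moved the number beyond the scatter.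

Compound 4 `COc1cc(-n2nnnc2-c2ccc(OCC3CC(c4ccc(C(F)(F)F)cc4)=NO3)c(N)c2)cc(OC)c1OC` is the next variation on the same position. Relative to compound 2 the change is 4-(trifluoromethyl)phenyl in place of 3,4-dimethoxyphenyl on a carbon with a double bond to nitrogen. The relevant precedent is the set of aryl exchanges above, all within the scatter, which points to a small step again. Going by the values given here, no measured compound carries a ring without hydrogen-bond acceptors at this position, so the direction is not anchored by data. The expectation is therefore a step of a 1.0-fold lower number from compound 2 to compound 4 (0.00 log units; within the scatter), with no change beyond the scatter in this assay. Compound 4 is estimated at 2500 nM, with a range of 1200 nM to 5500 nM.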

Compound 4, half-maximal inhibitory concentration: 1220 nM
For compound 4 the middle estimate is 2.0-fold (0.31 log units) above the measured one; the range from low to high includes it.
By their numbers in this assay, from the lowest: compounds 4, 1, 3 and 2 (each within the scatter of the next, the first and the last beyond it).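

In this assay, going by these compounds alone, this position shows for the first time a step that leaves the scatter: 4-(trifluoromethyl)phenyl, with 0 hydrogen-bond acceptors, replaces 3,4-dimethoxyphenyl, with 2, and gives a 2.1-fold lower number from compound 2 to compound 4 (0.32 log units; beyond the scatter), a modest change that shows the position is not wholly flat. The result holds against that one partner only, since the other two comparisons stay inside the scatter, with a 1.8-fold lower number from compound 3 to compound 4 (0.26 log units; within the scatter) and with a 1.6-fold lower number from compound 1 to compound 4 (0.20 log units; within the scatter), so compounds 1 and 3 go against any claim that 4-(trifluoromethyl)phenyl outperforms every aryl group seen here. No supporting measurement bears on why this exchange gives the step, and the four numbers alone cannot supply a reason.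

The compounds shown do not separate the arrival of the trifluoromethyl group from the departure of the two methoxy groups, a question that a plain phenyl, a 4-methoxyphenyl or a 4-chlorophenyl at this position would bear on. On these data alone, whether the step persists with a larger replacement, such as a naphthyl or a pyridyl ring, also remains open.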